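Two Weak Cell Inhibitors and an Untested Furan Analogue

The compounds below may be only part of what the source reports. "The series", "measured", "known", "first", "only" and "open" are said of these compounds alone.

Measured so far:
compound 1 `COc1cc(-c2cc(C(=O)O)c3ccccc3n2)ccc1OCC(=O)Nc1cccc(C)c1` gives 225000 nM
compound 2 `COc1cc(-c2cc(C(=O)O)c3ccccc3n2)ccc1OCC(=O)Nc1cccc(C(F)(F)F)c1` gives 160000 nM

In an ADME assay on HaCaT cells (Homo sapiens) for inhibition (a lower number here means a stronger inhibitor, a higher number a weaker inhibitor), compound 1 stands at the highest of the two numbers, and compound 2 lies within the scatter of it. The step of a 1.4-fold lower number from compound 1 to compound 2 (0.15 log units; within the scatter) is the only one recorded. Compound 3 `COc1cc(-c2cc(C(=O)O)c3ccccc3n2)ccc1OCC(=O)NCc1ccco1` changes the same amide end of compound 1, but more deeply: (furan-2-yl)methyl in place of 3-methylphenyl on an amide-type nitrogen. Going by the values given here, since the one known change at this end moved the number only within the scatter, a small step is expected, a 1.1-fold lower number from compound 1 to compound 3 (0.05 log units; within the scatter). Compound 3 is therefore estimated at 200000 nM, between 70000 nM and 600000 nM.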

Compound 3, half-maximal inhibitory concentration: > 300000 nM
Compound 3 gave a limit, no number; the forecaster's own chance of this, stated with the estimate: 25%; middle value at least 1.5-fold (0.17 log units) away from the limit.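

In this assay compound 3 gives only a limit, not a number: the limit of > 300000 nM in this assay, at which 1 of the 3 values shown sits.

As far as these compounds go, the steps read an at least 1.3-fold higher number from compound 1 to compound 3 (0.12 log units; that floor lies within the scatter) and an at least 1.8-fold higher number from compound 2 to compound 3 (0.27 log units; that floor lies within the scatter); both are floors, so their true size is unknown. Where the earlier pair changed only a group on the phenyl ring, replacing the whole 3-methylphenyl with (furan-2-yl)methyl on the amide-type nitrogen brings no stronger inhibition.

From the compounds shown here alone, how far compound 3 lies past its limit stays open. So does whether an amine or a carboxylic acid at this amide end would give a lower number.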